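Ring-size swap on the urea nitrogen of the quinolinone series

The compounds below may be only part of what the source reports. "The series", "measured", "known", "first", "only" and "open" are said of these compounds alone.

Measured so far:
compound 1 `O=C(NCCCOc1ccc2nc(O)ccc2c1)N(C1CC1)[C@@H]1CCC[C@H]1O` — 23%
compound 2 `O=C(NCCCOc1ccc2nc(O)ccc2c1)N(C1CC1)[C@@H]1CCCCC[C@H]1O` — 0%
compound 3 `O=C(NCCCOc1ccc2nc(O)ccc2c1)N(C1CCCCCCC1)[C@H]1CCCC[C@@H]1O` — 27%

In a functional assay on the whole organism for inhibition, with Rattus norvegicus as the target, at a dose of 30 mg/kg by the oral route (on this read-out higher numbers stand for more inhibition at the one dose given (going by the name of the read-out) and lower numbers for less inhibition), compound 3 gives the highest of the three numbers; compound 1 sits within the scatter of it, compound 2 well beyond it. Compound 4 `O=C(NCCCOc1ccc2nc(O)ccc2c1)N(C1CC1)[C@H]1CCCC[C@@H]1O` is reached from compound 3 by cyclopropyl in place of cyclooctyl on an amide-type nitrogen. For the measured compounds named here, no measured step changes this group; the only measured step, a number 23 percentage points lower from compound 1 to compound 2 (beyond the scatter), alters the hydroxycycloalkyl group instead, so its bearing is indirect. The shared cyclopropyl compounds 1 and 2 give the lower values in this assay, and compound 4 carries a hydroxycycloalkyl ring of size between those two. A modest downward step is therefore expected, a number 12 percentage points lower from compound 3 to compound 4 (beyond the scatter), with wide uncertainty. The estimate for compound 4 in this assay is 15%, between 0% and 35%.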

Compound 4, a percentage reported as inhibition, in the whole organism at one dose (the size of the read-out at that dose, not a potency): 13%
Estimate against measurement, compound 4: 2 percentage points above, and the stated range covers the measured number.
By their numbers in this assay, from the lowest: compound 2; then compounds 4, 1 and 3 (each within the scatter of the next, the first and the last beyond it).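

In this assay, for the compounds shown here, cyclopropyl in place of cyclooctyl on the amide-type nitrogen gives a number 14 percentage points lower from compound 3 to compound 4 (beyond the scatter) and is the first direct read of this position, with inhibition lost at the smaller ring. With cyclopropyl held, 2-hydroxycyclohexyl in place of 2-hydroxycycloheptyl gives a number 13 percentage points higher from compound 2 to compound 4 (beyond the scatter) while 2-hydroxycyclohexyl in place of 2-hydroxycyclopentyl gives a number 10 percentage points lower from compound 1 to compound 4 (within the scatter) and so the low number among the hydroxycycloalkyl rings belongs to compound 2 alone.

From the compounds shown here alone, whether cyclobutyl, cyclohexyl or an open-chain isopropyl on that nitrogen would hold the inhibition of cyclooctyl stays open. Nothing available accounts for these steps.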